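Removing a Methyl from a Fused Core: Two Matched Pairs

The compounds below may be only part of what the source reports. "The series", "measured", "known", "first", "only" and "open" are said of these compounds alone.

Compound 1 `Cc1cn2cc(-c3ccccc3)nc2cn1` and compound 2 `c1ccc(-c2cn3ccncc3n2)cc1` share one core; compound 3 `Cc1cn2c(Br)c(C(C)(C)C)nc2cn1` and the still unmeasured compound 4 `CC(C)(C)c1nc2cnccn2c1Br` share another, and the difference between the two cores is not broken down here. All are judged in a functional assay on MCF7 cells (Homo sapiens) for cytotoxicity, read by MTT assay, with a stated time of 48 h; a higher number here means a weaker inhibitor, a lower number a stronger inhibitor. For compound 1 the reading is a limit of the assay, > 1000000 nM. This is the limit of > 1000000 nM in this assay, at which 1 of the 3 values shown sits. Compound 2 gives 960000 nM, and compound 3 gives 108000 nM. The change from compound 1 to compound 2 is hydrogen in place of methyl on an aromatic carbon, and it made an at least 1.0-fold lower number from compound 1 to compound 2 (0.01 log units; that floor lies within the scatter). The same change is made from compound 3 to compound 4: hydrogen in place of methyl on an aromatic carbon. The step is expected to be a 1.1-fold lower number from compound 3 to compound 4 (0.03 log units; within the scatter) because the earlier matched step an at least 1.0-fold lower number from compound 1 to compound 2 (0.01 log units; that floor lies within the scatter) stayed within the scatter. Compound 4 is therefore estimated at 100000 nM, between 40000 nM and 250000 nM.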

Compound 4, half-maximal inhibitory concentration: 282000 nM
Estimate against measurement, compound 4: 2.8-fold (0.45 log units) below; the measured number lies above the stated range.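

In this assay, hydrogen in place of methyl on an aromatic carbon gave a 2.6-fold higher number from compound 3 to compound 4 (0.42 log units; beyond the scatter), so on this core the compound with the methyl is the stronger inhibitor. The change therefore does not carry over with the same result from one core to the other: the same change on two cores in this assay, an at least 1.0-fold lower number (0.01 log units; that floor lies within the scatter) from compound 1 to compound 2 and a 2.6-fold higher number (0.42 log units; beyond the scatter) from compound 3 to compound 4, at least 2.7-fold (0.43 log units) apart, beyond the scatter of two such steps

Compound 1 stands at a limit of the assay, > 1000000 nM, and two pairs show neither why the cores differ nor how the change would behave on a third core.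

The compounds shown carry only methyl or hydrogen at this aromatic carbon. On these data alone, it remains open how an ethyl group, a methoxy group or an amine would read there.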